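Diaryl ether thiosemicarbazones: partition estimate for the fluoro analogue

The source may hold more compounds than are shown below. What is called first, only, known or untested is meant among the compounds shown, and "the series" means these compounds.

Compound 1, `S=C(N/N=C/c1ccc(Oc2ccc(Cl)cc2)cc1)Nc1ccccc1`, in a physicochemical assay for lipophilicity, in phosphate buffer, measured as octanol-water partition, with a stated time of 24 h; a higher number here means a more lipophilic compound, a lower number a more polar compound: 5.52
Compound 2, `O=[N+]([O-])c1ccc(Oc2ccc(/C=N/NC(=S)Nc3ccccc3)cc2)cc1`, in this assay: 4.95
Compound 3, `Cc1cc(Oc2ccc(/C=N/NC(=S)Nc3ccccc3)cc2)ccc1Cl`, in this assay: 6.03

Compound 2 sits lowest of the three in this assay: the step of a number 0.57 log units lower from compound 1 to compound 2 (beyond the scatter) and the step of a number 1.08 log units higher from compound 2 to compound 3 (beyond the scatter) both separate it from the others beyond the scatter, with compound 3 furthest away.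

Compound 4, `O=[N+]([O-])c1ccc(Oc2ccc(/C=N/NC(=S)Nc3ccc(F)cc3)cc2)cc1`, is not yet measured. Its change from compound 2 is fluoro in place of hydrogen on an aromatic carbon, on an aromatic carbon of a six-membered aromatic ring of carbon only, para to a large group; one bond further out this reads phenyl to 4-fluorophenyl.

Among the measured compounds shown here, no measured step swaps fluoro for hydrogen, and none touches the anilino ring, so the bearing of the known steps is indirect. The nearest analogue is a number 0.51 log units higher from compound 1 to compound 3 (beyond the scatter), a small carbon substituent entering on an aromatic carbon. The nitro-for-chloro step a number 0.57 log units lower from compound 1 to compound 2 (beyond the scatter) concerns the other aryl ring and a different pair of groups. A single fluorine entering is expected to give at most a small shift upward in this assay, likely within the scatter.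

Compound 4 is therefore estimated at 5.1 in this assay, range 4.8 to 5.4. The expected step is a number 0.15 log units higher from compound 2 to compound 4 (within the scatter).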

Compound 4, partition coefficient: 4.89
Compound 4: the middle estimate sits 0.21 log units above what was measured; measured number inside the range.
By their numbers in this assay, from the lowest: compounds 4 and 2 (each within the scatter of the next); then compound 1; then compound 3.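

In this assay, among the compounds shown here, the first change on the anilino ring, fluoro in place of hydrogen para to a large group, gives a number 0.06 log units lower from compound 2 to compound 4 (within the scatter), so compound 2 and compound 4 cannot be told apart. The earlier steps shown here, all on the other aryl ring, lie beyond the scatter, among them a number 0.57 log units lower from compound 1 to compound 2 (beyond the scatter) and a number 0.51 log units higher from compound 1 to compound 3 (beyond the scatter); this one alone does not, so on the core of compound 2 the phenyl to 4-fluorophenyl change shows no readable effect on the read-out. Nothing among the available data accounts for this result at this position.

As far as these compounds go, whether a larger or ionisable group at the same place on the anilino ring, such as a carboxylic acid, a dimethylamino group or a trifluoromethyl group, would give a step beyond the scatter remains open. From the compounds shown here alone, the fluoro change also appears only with the 4-nitrophenyl group on the oxygen, so its size with the 4-chloro-3-methylphenyl group of compound 3 or on the core of compound 1 remains open as well.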